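Compound 3: a pyrimidine swap on the amide carbonyl

The compounds below may be only part of what the source reports. "The series", "measured", "known", "first", "only" and "open" are said of these compounds alone.

Values so far in a physicochemical assay for solubility, at pH 6.8; a lower number here means a less soluble compound, a higher number a more soluble compound
- compound 1 `COCC(=O)N[C@@H](C)c1ccc(NC(=O)[C@H]2C[C@@H]2c2cccnc2)cc1` gives 520000 nM
- compound 2 `C[C@H](NC(=O)c1ccccn1)c1ccc(NC(=O)[C@H]2C[C@@H]2c2cccnc2)cc1` gives 10000 nM

Of these two numbers, compound 2 holds the lower. Among the measured compounds shown here, the single measured step is large: a 52-fold lower number from compound 1 to compound 2 (1.72 log units; beyond the scatter), with pyridin-2-yl in place of methoxymethyl on a carbonyl carbon.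

Next comes compound 3 `C[C@H](NC(=O)c1ncccn1)c1ccc(NC(=O)[C@H]2C[C@@H]2c2cccnc2)cc1`, with pyrimidin-2-yl in place of pyridin-2-yl on a carbonyl carbon.

For the measured compounds named here, the measured step sits at this same carbonyl carbon and is the only guide. It replaced a chain with a ring, whereas here one six-membered aromatic ring replaces another, so a much smaller step is expected. One step cannot settle the direction, and a modest rise is only a working expectation. In this assay the expected step is a 2.5-fold higher number from compound 2 to compound 3 (0.40 log units; beyond the scatter).

The estimate for compound 3 is 25000 nM, with an expected range of 8000 nM to 80000 nM.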

Compound 3, solubility: 27000 nM
Compound 3: middle estimate off by 1.1-fold (0.03 log units), on the low side; measured number inside the range.
By their numbers in this assay, from the lowest: compound 2; then compound 3; then compound 1.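

Pyrimidin-2-yl in place of pyridin-2-yl gives a 2.7-fold higher number from compound 2 to compound 3 (0.43 log units; beyond the scatter) in this assay, so this position responds to a change inside the aromatic ring at an unchanged heavy atom count, and not only to a chain giving way to a ring. The second ring nitrogen recovers only part of the earlier drop: pyrimidin-2-yl in place of methoxymethyl still gives a 19-fold lower number from compound 1 to compound 3 (1.28 log units; beyond the scatter) and the methoxymethyl amide keeps the highest number of the three. No measurement at hand gives a reason for either step.

The compounds shown leave open whether a saturated ring such as morpholine at this carbonyl carbon would stay near the aromatic rings or come closer to methoxymethyl. They also leave open how a longer ether chain or a chain carrying a dimethylamino group would compare with methoxymethyl.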